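Cytotoxicity notes on three measured compounds and one pending

The source may report more compounds than this note shows. Statements on the series, on what has been measured and on what is new or still open speak of the compounds shown alone.

Measured so far in an ADME assay on A549 cells (Homo sapiens) for cytotoxicity, read by CellTiter-Glo; on this read-out lower numbers stand for higher toxicity in this test and higher numbers for lower toxicity in this test:
compound 1 `Cc1c(Cc2ccc(OC(F)(F)F)cc2)c(=O)oc2cc(OCC(O)CN3CCC(C(N)=O)CC3)ccc12` gives 68200 nM
compound 2 `Cc1c(Cc2ccc(-c3ccccc3)cc2)c(=O)oc2cc(OCC(O)CN3CCC(C(N)=O)CC3)ccc12` gives > 100000 nM
compound 3 `Cc1c(Cc2ccc(OC(F)(F)F)cc2)c(=O)oc2cc(OCC(O)CNc3nccs3)ccc12` gives 99000 nM

The value of compound 2 is a limit of the assay, not a number, (the limit of > 100000 nM in this assay, at which 1 of the 3 values shown sits). The change between compound 1 and compound 2 is phenyl in place of trifluoromethoxy on an aromatic carbon, and it made an at least 1.4-fold higher number from compound 1 to compound 2 (0.16 log units; that floor lies within the scatter). The two cores differ by (1,3-thiazol-2-yl)amino in place of 4-carbamoylpiperidin-1-yl on a saturated chain carbon, two bonds along the chain from an oxygen on a saturated carbon, which made a 1.5-fold higher number from compound 1 to compound 3 (0.16 log units; within the scatter).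

Compound 4 `Cc1c(Cc2ccc(-c3ccccc3)cc2)c(=O)oc2cc(OCC(O)CNc3nccs3)ccc12` has not been measured in this assay. Among the compounds with values here, it differs from compound 3 by phenyl in place of trifluoromethoxy on an aromatic carbon, the same change at the same place as the one between compound 1 and compound 2.

The step is expected to repeat, a 1.5-fold higher number from compound 3 to compound 4 (0.18 log units; within the scatter), resting on compound 1 and its step of an at least 1.4-fold higher number from compound 1 to compound 2 (0.16 log units; that floor lies within the scatter) and on compound 3 starting from 99000 nM. Compound 4 is therefore expected around 150000 nM, between 80000 nM and 300000 nM, and most likely to be reported only as a limit.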

Compound 4, half-maximal cytotoxic concentration: 38100 nM
Estimate against measurement, compound 4: 3.9-fold (0.60 log units) above; measured number outside the range, below it.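

In this assay, phenyl in place of trifluoromethoxy gives a 2.6-fold lower number from compound 3 to compound 4 (0.41 log units; beyond the scatter), and the change of the amine side chain on the phenyl compounds gives an at least 2.6-fold lower number from compound 2 to compound 4 (0.41 log units; beyond the scatter). The phenyl change therefore does not carry unchanged from the core of compound 1 to the core of compound 3: the same change on two cores in this assay, an at least 1.4-fold higher number (0.16 log units; that floor lies within the scatter) from compound 1 to compound 2 and a 2.6-fold lower number (0.41 log units; beyond the scatter) from compound 3 to compound 4, at least 3.8-fold (0.58 log units) apart, beyond the scatter of two such steps Compound 2 gives > 100000 nM, a limit of the assay and not a number, so its step is only a floor, and a single pair of cores shows that the change can fail to carry, not how often this happens or what lies behind it.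

Going by these compounds, whether the two steps also part with a simple primary amine or a carboxylic acid in place of (1,3-thiazol-2-yl)amino stays open. The same holds for a nitrile in place of trifluoromethoxy.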